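The compounds below may be only part of what the source reports. "The series", "measured", "known", "first", "only" and "open" are said of these compounds alone.

In a functional assay on PC-3 cells (Homo sapiens) for antiproliferative activity, read by MTT assay, with a stated time of 72 h (on this read-out lower numbers stand for stronger inhibition and higher numbers for weaker inhibition), compound 1 (`O=S(=O)(c1ccc(-c2cnc(C3CC3)o2)cc1)N1CCCOc2ccccc21`) gives 27 nM and compound 2 (`O=[N+]([O-])c1ccc2c(c1)N(S(=O)(=O)c1ccc(-c3cnc(C4CC4)o3)cc1)CCCO2`) gives 119 nM, so compound 2 has the higher of the two numbers and is the weaker inhibitor of the pair. Compound 3 (`COc1ccc2c(c1)N(S(=O)(=O)c1ccc(-c3cnc(C4CC4)o3)cc1)CCCO2`) keeps the core of compound 2 but carries methoxy in place of nitro on an aromatic carbon. Among the compounds with values here, only one measured step bears on this change. It is a 4.4-fold higher number from compound 1 to compound 2 (0.64 log units; beyond the scatter), where nitro took the place of hydrogen on an aromatic carbon. Within the data shown here, that step is modest, and no measured compound carries methoxy, so the data say nothing directly about this group. With nitro gone, the number is expected to move back towards that of compound 1, 27 nM, without necessarily reaching it. The expected change in this assay is therefore a modest one towards a lower number, estimated as a 2.6-fold lower number from compound 2 to compound 3 (0.42 log units; beyond the scatter). For compound 3 the estimated value is 45 nM, with an expected range from 15 nM to 130 nM.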

Compound 3, half-maximal inhibitory concentration: 14 nM
For compound 3 the middle estimate is 3.2-fold (0.51 log units) above the measured one; the measured number lies below the stated range.
By their numbers in this assay, from the lowest: compounds 3 and 1 (each within the scatter of the next); then compound 2.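

In this assay, the position on this aromatic carbon proves sensitive to which group sits there, not only to whether a group is present at all: methoxy in place of nitro gives an 8.5-fold lower number from compound 2 to compound 3 (0.93 log units; beyond the scatter) and so undoes the loss seen with nitro. Methoxy in place of hydrogen gives a 1.9-fold lower number from compound 1 to compound 3 (0.29 log units; within the scatter), so compound 3 and compound 1 cannot be told apart, and this carbon can carry methoxy with no readable loss; the earlier pair alone could not show that the loss belongs to nitro rather than to any group placed here. No accompanying measurement offers an explanation for the difference between nitro and methoxy at this place.

The compounds shown cover only hydrogen, nitro and methoxy on this carbon, so it remains open whether an amine, a chlorine atom or a longer chain such as ethoxy would stay level with compound 1 and compound 3 or fall back towards compound 2. Going by these compounds, it is also open whether methoxy would behave the same way on another carbon of this ring.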